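The compounds below may be only part of what the source reports. "The series", "measured", "known", "first", "only" and "open" are said of these compounds alone.

Compounds measured in a toxicity assay on THP-1 cells (Homo sapiens) for inhibition; a lower number here means that less compound is tolerated, a higher number that more compound is tolerated:
- Compound 1 `COc1ccc(-c2cnc(NC(=O)c3ccc(F)cc3)n2Cc2ccccc2)cc1` | > 100000 nM
- Compound 2 `COc1ccc(-c2cn(C)c(NC(=O)c3ccc(F)cc3)n2)cc1` | > 50000 nM
- Compound 3 `COc1ccc(-c2cnc(NC(=O)c3cnco3)n2C)cc1` | > 100000 nM

All three entries are limits, not numbers. Compound 1 stands at a limit (the limit of > 100000 nM in this assay, at which 2 of the 3 values shown sit), so no number exists for it. No measured step connects any two of these compounds.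

Compound 4 `CCCCn1c(-c2ccc(OC)cc2)cnc1NC(=O)c1ccc(F)cc1` has propyl in place of phenyl on a saturated chain carbon bound to an aromatic nitrogen, which reads as benzyl to butyl (propyl in place of phenyl on a saturated chain carbon bound to an aromatic nitrogen). In this assay, no change beyond the scatter is expected, in either direction. The expectation rests on compound 1 alone, whose value (> 100000 nM) is a limit. The expected change is small (an at least 1.1-fold lower number from compound 1 to compound 4 (0.04 log units; that floor lies within the scatter)). For compound 4 the estimated value is 90000 nM, within an expected range of 35000 nM to 200000 nM, and the assay may again report only a limit.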

Compound 4, half-maximal cytotoxic concentration: > 100000 nM
Compound 4: a limit, no number; the forecaster's own chance of this, stated with the estimate: 75%; middle value at least 1.1-fold (0.04 log units) away from the limit.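

In this assay compound 4 gives > 100000 nM, a limit. With compound 1 also at a limit, the step from benzyl to butyl cannot be read. The compounds shown leave open at what concentration any of them becomes cytotoxic.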